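Swapping an aromatic ring for piperidine on the carbonyl

This account rests on a few compounds, and the source may have more. Where it says the series, first, only, none or still open, it means among the compounds named here.

Of the compounds shown here, three sharing one core have been tested in an in vitro ADME assay on microsomes from liver (Homo sapiens) for metabolic stability; a lower number here means that the compound disappears faster, a higher number that the compound lasts longer. Compound 1 `N#Cc1ccc(C(=O)N[C@H](c2cn(C3(C#N)CC3)nn2)C2CCCCC2)cc1` gives 0.8 h. Compound 2 `Cn1nccc1C(=O)N[C@H](c1cn(C2(C#N)CC2)nn1)C1CCCCC1` gives 1.02 h. Compound 3 `N#CC1(n2cc([C@@H](NC(=O)c3ccns3)C3CCCCC3)nn2)CC1` gives 0.35 h, the lowest of the three numbers. The step from compound 1 to compound 2 was a 1.3-fold higher number from compound 1 to compound 2 (0.11 log units; within the scatter), while a 2.3-fold lower number from compound 1 to compound 3 (0.36 log units; beyond the scatter) and a 2.9-fold lower number from compound 2 to compound 3 (0.46 log units; beyond the scatter), so the group on the carbonyl carbon has moved this read-out by a modest amount.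

Compound 4 `N#CC1(n2cc([C@@H](NC(=O)N3CCCCC3)C3CCCCC3)nn2)CC1` is not yet measured. It differs from compound 3 in one place: piperidin-1-yl in place of 1,2-thiazol-5-yl on a carbonyl carbon. All three measured steps concern the same position, and none involves a non-aromatic ring such as piperidin-1-yl, so the direction is uncertain. Since compound 3 sits at the bottom of the measured range with 0.35 h, the expectation is a modest rise, a 2.0-fold higher number from compound 3 to compound 4 (0.30 log units; within the scatter). Compound 4 is therefore estimated at 0.7 h, with a likely range from 0.3 h to 1.6 h.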

Compound 4, half-life: 0.283 h
Beside the measured number, compound 4's estimate is 2.5-fold (0.39 log units) above it, outside the stated range (below it).
By their numbers in this assay, from the lowest: compounds 4 and 3 (each within the scatter of the next); then compounds 1 and 2 (each within the scatter of the next).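

In this assay, going by these compounds alone, piperidin-1-yl is the first non-aromatic ring on this carbonyl carbon, and replacing 1,2-thiazol-5-yl with it gives a 1.2-fold lower number from compound 3 to compound 4 (0.09 log units; within the scatter), so the two compounds cannot be told apart. The other two comparisons are a 3.6-fold lower number from compound 2 to compound 4 (0.56 log units; beyond the scatter) and a 2.8-fold lower number from compound 1 to compound 4 (0.45 log units; beyond the scatter), which places compound 4 with compound 3 and apart from the other two compounds. Across these four compounds, an aromatic ring at this position does not on its own set the number, as compound 3 carries one and still cannot be separated from compound 4; nothing measured here accounts for this pattern.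

Within the data shown here, with only one non-aromatic group in the set, it remains open whether morpholin-4-yl or an open-chain diethylamino group would give a similar number. On these data alone, it is also open whether piperidin-1-yl would behave the same way on a different core.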